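The source may hold more compounds than are shown below. What is called first, only, known or untested is meant among the compounds shown, and "the series" means these compounds.

In an ADME assay on L929 cells (Mus musculus) for cytotoxicity, read by resazurin assay, with a stated time of 48 h (a higher number here means that more compound is tolerated, a lower number that less compound is tolerated), compound 1 (`O=c1c2cc([N+](=O)[O-])ccc2n(CCO)n1Cc1ccccc1`) gives > 256000 nM as a limit of the assay. Compound 2 (`CC(=O)OCCn1c2ccc([N+](=O)[O-])cc2c(=O)n1Cc1ccccc1`) gives > 256000 nM as a limit too. Among the measured compounds shown here, the one measured step (a step that the two limits leave unreadable from compound 1 to compound 2) has no readable size, and compound 2 stands at the limit of > 256000 nM in this assay, at which 2 of the 2 values shown sit, with nothing further to go on. Compound 3 (`CCOC(=O)n1c2ccc([N+](=O)[O-])cc2c(=O)n1Cc1ccccc1`) carries ethoxycarbonyl in place of 2-acetoxyethyl on an aromatic nitrogen. For the measured compounds named here, with only that unreadable step to draw on, no step beyond the scatter is expected in this assay here. The estimated step (an at least 1.1-fold lower number from compound 2 to compound 3 (0.04 log units; that floor lies within the scatter)) is read in that sense. For compound 3 the estimate is 230000 nM with an expected range from 100000 nM to 256000 nM in this read-out.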

Compound 3, concentration lethal to 50% of the cells: 122000 nM
Compound 3: the middle estimate sits 1.9-fold (0.28 log units) above what was measured; measured number inside the range.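

In this assay, ethoxycarbonyl on the aromatic nitrogen in place of 2-acetoxyethyl gives an at least 2.0-fold lower number from compound 2 to compound 3 (0.32 log units; beyond the scatter), and in place of 2-hydroxyethyl it gives an at least 2.0-fold lower number from compound 1 to compound 3 (0.32 log units; beyond the scatter). This position therefore yields readable steps, whereas the acetyl change on the oxygen of compound 1 left its step unreadable. Both new steps remain floors rather than full sizes: the limit of > 256000 nM in this assay, at which 2 of the 3 values shown sit.

Still open, as far as these compounds go, is whether the drop follows the carbonyl on the aromatic nitrogen or the loss of the ethyl link. From the compounds shown here alone, it is also open how an amine or a carboxylic acid at the end of the 2-hydroxyethyl chain would read at this position.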